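Carboxyphenyl regioisomers on a propylene-linked diaryl ether scaffold

The source may hold more compounds than are shown below. What is called first, only, known or untested is meant among the compounds shown, and "the series" means these compounds.

Measured compounds:
compound 1 `Cc1c(O[C@H](C)COc2ccc(F)c(C(=O)O)c2)ccc(C(=O)CC(C)(C)C)c1O` gives 2410 nM
compound 2 `Cc1ccc(OC[C@H](C)COc2ccc(C(=O)CC(C)(C)C)c(O)c2C)cc1C(=O)O` gives > 10000 nM

In an assay for positive allosteric modulation of metabotropic glutamate receptor 3 (Rattus norvegicus) (on this read-out higher numbers stand for an effect only at larger amounts of compound and lower numbers for an effect already at smaller amounts), compound 1 gives 2410 nM. For compound 2 only a limit is known: in this assay compound 2 gives > 10000 nM, which is a limit of the assay and not a measured number (the limit of > 10000 nM in this assay, at which 1 of the 2 values shown sits). No step between the two measured compounds is shown, so they are set side by side without further comparison.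

Compound 3 `Cc1cc(C(=O)O)ccc1OC[C@H](C)COc1ccc(C(=O)CC(C)(C)C)c(O)c1C` differs from compound 2 in the arrangement of the same atoms: 4-carboxy-2-methylphenyl in place of 3-carboxy-4-methylphenyl on an oxygen on a saturated carbon. With compound 2 sitting at the limit of this assay, the step is expected to stay small, with a fair chance that compound 3 also returns only a limit; the expected step is a step that the limit leaves unreadable from compound 2 to compound 3. Compound 3 is expected to give 12000 nM in this assay, with a range from 3000 nM to 40000 nM.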

Compound 3, half-maximal effective concentration: 1520 nM
Estimate against measurement, compound 3: 7.9-fold (0.90 log units) above; measured number below the stated range.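

In this assay, 4-carboxy-2-methylphenyl in place of 3-carboxy-4-methylphenyl on the oxygen on a saturated carbon gives an at least 6.5-fold lower number from compound 2 to compound 3 (0.81 log units; beyond the scatter). No atom is added or lost in this change, so the arrangement of the same atoms on this ring alone separates a compound with a readable number from one without. For compound 2, > 10000 nM is a limit and not a number, so the step has a lower bound but no known full size: the limit of > 10000 nM in this assay, at which 1 of the 3 values shown sits.

Both the carboxy and the methyl group shift in this one step, and the compounds shown do not separate their shares in the change. They also leave open how an amide or a tetrazole in place of the carboxylic acid on this ring would read out.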